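Piperidine for dimethylamino: a step with little expected change

The source may hold more compounds than are shown below. What is called first, only, known or untested is meant among the compounds shown, and "the series" means these compounds.

Compound 1 `O=C(CCN1CCCCC1)c1cc2ccc(O)cc2oc1=O`: 45400 nM
Compound 2 `Cc1cc(O)cc2oc(=O)c(C(=O)CCN(C)C)cc12`: 25700 nM

Both values come from a functional assay on SH-SY5Y cells (Homo sapiens) for cytotoxicity, read by MTT assay, with stated times of 1 h and 24 h; a lower number here means that less compound is needed, a higher number that more compound is needed for the effect. With 25700 nM, compound 2 stands within the usual scatter of compound 1, so these two numbers set no order. Compound 3 `Cc1cc(O)cc2oc(=O)c(C(=O)CCN3CCCCC3)cc12` has not been measured yet. It keeps the core of compound 2 and differs in one place: piperidin-1-yl in place of dimethylamino on a saturated chain carbon, two bonds along the chain from a carbonyl carbon. This puts piperidin-1-yl in place of dimethylamino on a saturated chain carbon, two bonds along the chain from a carbonyl carbon. Going by the values given here, no measured pair isolates this change, so its size cannot be read directly. Compound 1 also carries piperidin-1-yl and gives 45400 nM, within the scatter of compound 2. On that basis, no step beyond the scatter is expected in this assay. The expected step of a 1.2-fold higher number from compound 2 to compound 3 (0.10 log units; within the scatter) is small. For compound 3 the estimated value is 32000 nM, with an expected range of 14000 nM to 70000 nM.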

Compound 3, half-maximal effective concentration: > 100000 nM
Compound 3: no number, only a limit; the forecaster's own chance of this, stated with the estimate: 8%; middle value at least 3.1-fold (0.49 log units) away from the limit.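

Placed on the core of compound 2, piperidin-1-yl in place of dimethylamino on a saturated chain carbon, two bonds along the chain from a carbonyl carbon, gives an at least 3.8-fold higher number from compound 2 to compound 3 (0.59 log units; beyond the scatter), so in this assay this change does shift the result. With piperidin-1-yl kept, methyl in place of hydrogen on an aromatic carbon gives an at least 2.2-fold higher number from compound 1 to compound 3 (0.34 log units; beyond the scatter), so the two compounds carrying piperidin-1-yl are also separated by that single methyl group. On these data alone, compound 3 has only a limit rather than a number, so the full size of both steps remains unknown: the limit of > 100000 nM in this assay, at which 1 of the 3 values shown sits.

As far as these compounds go, it remains open how other amines would behave at this place, such as pyrrolidin-1-yl, with its five-membered ring, or morpholin-4-yl, with its ring oxygen. A longer chain between the carbonyl and the amine is also untested among the compounds shown.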